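The source may report more compounds than this note shows. Statements on the series, on what has been measured and on what is new or still open speak of the compounds shown alone.

Compound 1, whose structure is `CC(C)(C)Cc1c(-c2ccc(F)cc2F)sc(N)c1C(=O)c1ccc(Cl)cc1`, was tested in an assay on CHO cells for displacement of a labelled ligand from adenosine receptor A3 (Homo sapiens), read by scintillation counting, tested at 10 uM (on this read-out higher numbers stand for more inhibition at the one concentration tested (going by the name of the read-out) and lower numbers for less inhibition), and there compound 1 gives 1%. For the measured compounds named here, the only other measured member of this small series is compound 2, with structure `CC(C)(C)Cc1c(-c2ccccc2)sc(N)c1C(=O)c1ccc(Cl)cc1Cl`, and in this assay compound 2 gives 1%. On these numbers compound 1 stands level with compound 2 at the digits reported, and the two values lie within the usual scatter of each other, so nothing can be said about one being stronger than the other. Going by the values given here, no pair of measured compounds differing in a single place is available, so no measured step can guide the next change.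

Compound 3, with structure `CC(C)(C)Cc1c(-c2cn[nH]c2)sc(N)c1C(=O)c1ccc(Cl)cc1`, has not yet been measured in this assay. Its difference from compound 1 is 1H-pyrazol-4-yl in place of 2,4-difluorophenyl on an aromatic carbon. Since compound 1 gives 1% and compound 2 gives 1%, both at the bottom of the scale, the step from compound 1 to compound 3 is expected to be a number 2 percentage points higher from compound 1 to compound 3 (within the scatter), that is, no change beyond the scatter. Compound 3 is therefore estimated at 3%, in a range from 0% to 15%.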

Compound 3, a percentage reported as inhibition, at one concentration (the size of the read-out at that concentration, not a potency): 1%
Beside the measured number, compound 3's estimate is 2 percentage points above it; the measured number falls inside the stated range.
By their numbers in this assay, from the lowest: compounds 1, 2 and 3 (each within the scatter of the next).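

Putting 1H-pyrazol-4-yl in place of 2,4-difluorophenyl on the aromatic carbon next to the ring sulfur gave, in this assay, no change at the digits printed from compound 1 to compound 3 (within the scatter). For the compounds shown here, this is the first step that changes one place only, and it shows that exchanging a six-membered aromatic ring of carbon only for a five-membered aromatic ring with 2 hetero atoms, which brings in a hydrogen-bond donor and a hydrogen-bond acceptor, leaves the read-out where it stood for compound 1. Nothing measured here offers an explanation for this result.

With all the compounds shown at one level at the bottom of the scale, they leave open whether any group at this position can raise inhibition at the one concentration tested, or whether the read-out stays this low whatever stands there. Also open, from the compounds shown here alone, is what a carboxylic acid or an aminomethyl group would give at this place, and what an ethyl chain would give in place of the neopentyl group.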